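A few compounds are considered here, and "the series" means these few. Any claim that something is new, unique, unknown or untested is made for them only; others in the source may bear on it.

In a functional assay on NCI-H460 cells (Homo sapiens) for antiproliferative activity, with a stated time of 72 h (on this read-out lower numbers stand for stronger inhibition and higher numbers for weaker inhibition), compound 1 (`C=C[C@@H]1C[C@@H](Cc2ccc(OC)c(O)c2)[C@H]2C(=O)C=CC(=C)[C@H]21`) gives 14.5 nM as its result. Compound 2 (`C=C1C=CC(=O)[C@@H]2[C@H](Cc3ccc(OCOC)cc3)CC[C@H]12`) gives 226 nM and so holds the higher of the two numbers, which makes it the weaker inhibitor of the pair by a gap beyond the scatter. These two compounds differ in more than one place, so their gap cannot be tied to any single change. Compound 3 (`C=C1C=CC(=O)[C@@H]2[C@H](Cc3ccc(OCOC)c(F)c3)CC[C@H]12`) comes from compound 2 through one change (fluoro in place of hydrogen on an aromatic carbon): fluoro in place of hydrogen on an aromatic carbon, ortho to a methoxymethoxy group. For the measured compounds named here, no measured pair shows what a single swap of this kind does, so the forecast is loose. In this assay no step beyond the scatter is expected, and the estimated move (a 1.3-fold lower number from compound 2 to compound 3 (0.12 log units; within the scatter)) is a small one. For compound 3 the estimated value is 170 nM with an expected range from 60 nM to 500 nM on this measure.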

Compound 3, half-maximal inhibitory concentration: 106 nM
The estimate for compound 3 lay 1.6-fold (0.21 log units) above the measured number; the range from low to high includes it.
By their numbers in this assay, from the lowest: compound 1; then compound 3; then compound 2.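

In this assay the swap of hydrogen for fluoro on the aromatic carbon ortho to the methoxymethoxy group gives a 2.1-fold lower number from compound 2 to compound 3 (0.33 log units; beyond the scatter) as a modest step, yet one beyond the usual scatter. For the compounds shown here, this is the first comparison here between compounds that differ in only one place, and it shows that this position accepts a fluorine atom with a small gain in antiproliferative activity rather than a loss. Nothing available accounts for the gain, so it stands as an observation only.

On these data alone, whether a chloro or a methoxy group at the same carbon would move the number in the same direction stays open. As far as these compounds go, it is also open whether fluoro would give a similar step on the core of compound 1, whose aromatic ring carries different groups.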